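This account rests on a few compounds, and the source may have more. Where it says the series, first, only, none or still open, it means among the compounds named here.

Two compounds have been measured so far in a functional assay for inhibition of sodium/hydrogen exchanger (Oryctolagus cuniculus); on this read-out higher numbers stand for weaker inhibition and lower numbers for stronger inhibition:

compound 1 `CCCc1cc(C)c(C(=O)N=C(N)N)cc1S(C)(=O)=O` — 5.7 nM
compound 2 `Cc1cc(-c2ccc(F)cc2)c(S(C)(=O)=O)cc1C(=O)N=C(N)N` — 36 nM

Going by the values given here, on these two numbers compound 2 stands highest; its only neighbour is compound 1, and the step of a 6.3-fold higher number from compound 1 to compound 2 (0.80 log units; beyond the scatter) sets the two apart beyond the scatter. The next compound, compound 3 `CSc1cc(C)c(C(=O)N=C(N)N)cc1S(C)(=O)=O`, differs from compound 2 in one place: methylsulfanyl in place of 4-fluorophenyl on an aromatic carbon.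

Among the compounds with values here, only one measured step bears on this change, and only indirectly. The step of a 6.3-fold higher number from compound 1 to compound 2 (0.80 log units; beyond the scatter) showed that exchanging a short propyl chain for the 4-fluorophenyl group raised the number modestly. Compound 3 removes that same 4-fluorophenyl group again, but what enters is methylsulfanyl, not propyl, so the return cannot be assumed to be exact. Nothing measured here speaks to methylsulfanyl itself.

Working from that single step, compound 3 is expected to move back toward the level of compound 1, the estimated step being a 4.5-fold lower number from compound 2 to compound 3 (0.65 log units; beyond the scatter) in this assay. For compound 3 the estimate in this assay is therefore 8 nM, with a range from 3 nM to 25 nM.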

Compound 3, half-maximal inhibitory concentration: 6 nM
Estimate against measurement, compound 3: 1.3-fold (0.12 log units) above, within the range that was stated.
By their numbers in this assay, from the lowest: compounds 1 and 3 (each within the scatter of the next); then compound 2.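

Replacing the 4-fluorophenyl group with methylsulfanyl at this aromatic carbon gives a 6.0-fold lower number from compound 2 to compound 3 (0.78 log units; beyond the scatter) in this assay, so the step away from the ring-bearing group is now measured directly rather than inferred from propyl alone. The pair that differs only between propyl and methylsulfanyl gives a 1.1-fold higher number from compound 1 to compound 3 (0.02 log units; within the scatter), so these two non-ring groups cannot be told apart in this assay, even though one carries sulfur and a hydrogen-bond acceptor; among the three compounds, only compound 2, with its 4-fluorophenyl group, stands apart from the others. No measurement offered here explains why the ring-bearing compound gives the higher number or why the two smaller groups match.

The compounds shown leave open whether the higher number of compound 2 goes with the aromatic ring itself or with the fluorine on it, a question that a plain phenyl group at this carbon would address. They also leave open how far this level extends to other small groups here, such as methoxy, an amine or a longer chain like pentyl.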